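Swapping a Nitrile for a Thioamide on Two Sugar Cores

A few compounds are considered here, and "the series" means these few. Any claim that something is new, unique, unknown or untested is made for them only; others in the source may bear on it.

Compound 1 `N#Cc1cn([C@H]2C[C@H](O)[C@@H](CO)O2)c2ncnc(N)c12` carries a cyano group on a two-ring aromatic core attached to a sugar bearing a hydroxyl group. In a functional assay on KB cells (Homo sapiens) for inhibition (on this read-out higher numbers stand for weaker inhibition and lower numbers for stronger inhibition), compound 1 gives 25000 nM. Compound 3 `NC(=S)c1cn([C@H]2C[C@H](O)[C@@H](CO)O2)c2ncnc(N)c12` is its counterpart in which the cyano group has been replaced: a group of 3 heavy atoms (1 carbon, 1 nitrogen, 1 sulfur; no ring) in place of a group of 2 heavy atoms (1 carbon, 1 nitrogen; no ring), on an aromatic carbon. In this assay compound 3 gives 7000 nM, which amounts to a 3.6-fold lower number from compound 1 to compound 3 (0.55 log units; beyond the scatter).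

Compound 2 `N#Cc1cn(C2C=CC(CO)O2)c2ncnc(N)c12` has the same cyano group on a core with a different sugar; the difference between the two cores is not broken down here. In this assay compound 2 gives 176000 nM, the highest of the three numbers. Compound 4 `NC(=S)c1cn(C2C=CC(CO)O2)c2ncnc(N)c12`, not yet measured, carries the same replacement on the core of compound 2: a group of 3 heavy atoms (1 carbon, 1 nitrogen, 1 sulfur; no ring) in place of a group of 2 heavy atoms (1 carbon, 1 nitrogen; no ring), on an aromatic carbon. Around the place the surroundings differ slightly, since the group borne by the other ring atom is not the same in compound 2 as in compound 1, so this is the same kind of change rather than the same change.

Because the earlier replacement gave a 3.6-fold lower number from compound 1 to compound 3 (0.55 log units; beyond the scatter), the step from compound 2 to compound 4 in this assay is expected to be a 3.5-fold lower number from compound 2 to compound 4 (0.55 log units; beyond the scatter). The value of compound 4 in this assay is estimated at 50000 nM. For the measured compounds named here, the expected range for compound 4 runs from 15000 nM to 160000 nM, kept wide since only one earlier instance of this change is known and the two cores differ.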

Compound 4, half-maximal inhibitory concentration: 5000 nM
For compound 4 the middle estimate is 10-fold (1.00 log units) above the measured one; the whole stated range lies above it.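

In this assay, replacing the cyano group with the thioamide on the core of compound 2 gives a 35-fold lower number from compound 2 to compound 4 (1.55 log units; beyond the scatter). For the compounds shown here, the number falls on both cores, so in these two pairs the direction of the change carries over, while its size does not: the same change on two cores in this assay, a 3.6-fold lower number (0.55 log units; beyond the scatter) from compound 1 to compound 3 and a 35-fold lower number (1.55 log units; beyond the scatter) from compound 2 to compound 4, 9.9-fold (0.99 log units) apart, beyond the scatter of two such steps The pairs show that the gain measured on one core was a poor guide to the size of the gain on the other, but with only two cores they give no general rule for this series, and they do not show which structural difference between the cores goes with the larger step or why the step differs.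

From the compounds shown here alone, it remains open whether other groups on the same aromatic carbon, such as an ordinary amide with oxygen in place of sulfur, a carboxylic acid or an amine, would also lower the number on both cores and differ in size from one core to the other. Going by these compounds, it is also open whether the same replacement on a third sugar would give a step close to the smaller one, close to the larger one or somewhere else entirely.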